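The compounds below may be only part of what the source reports. "The series", "measured", "known", "first", "only" and "open" are said of these compounds alone.

Measured compounds:
compound 1, `CCC1=C(N2CC2)C(=O)C(CCOC(N)=O)=C(N2CC2)C1=O`, 5.98 in a functional assay on L1210 cells (Mus musculus), with a stated time of 1 days; a lower number here means a less potent compound, a higher number a more potent compound, by a factor of ten per unit of this negative logarithm;
compound 2, `CCCC1=C(N2CC2)C(=O)C(CCOC(N)=O)=C(N2CC2)C1=O`, 4.9.

Compound 1 stands highest of the two numbers; its nearest neighbour is compound 2, and the step of a number 1.08 log units lower from compound 1 to compound 2 (beyond the scatter) lies beyond the scatter. Compound 3, `CCC1=C(N2CC2)C(=O)C(CC)=C(N2CC2)C1=O`, differs from compound 1 by hydrogen in place of carbamoyloxy on a saturated chain carbon, two bonds along the chain from a double-bonded ring carbon. Going by the values given here, no measured step covers this change: the one step known alters a different chain, so it gives no direct guide. The carbamoyloxy group counts one hydrogen-bond donor and two acceptors, and its loss is expected to lower potency somewhat. Compound 3 is expected at 5.3, between 4.5 and 6.1. The expected step of a number 0.68 log units lower from compound 1 to compound 3 (beyond the scatter) is an estimate only.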

Compound 3, logarithm of the reciprocal of the active concentration, log(1/C): 4.94
Estimate against measurement, compound 3: 0.36 log units above, within the range that was stated.
By their numbers in this assay, from the lowest: compounds 2 and 3 (each within the scatter of the next); then compound 1.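

Removing the carbamoyloxy group, so that 2-(carbamoyloxy)ethyl becomes ethyl, gives a number 1.04 log units lower from compound 1 to compound 3 (beyond the scatter) in this assay and shows that this chain also counts for the read-out. Compound 1 now loses potency on a single change at either chain, the other being a number 1.08 log units lower from compound 1 to compound 2 (beyond the scatter) on the shared core. No data at hand explain the drop. From the compounds shown here alone, it remains open whether the carbamoyloxy group itself is required, or whether a hydroxyl, an amine or a carboxylic acid on the same chain carbon would hold the potency of compound 1.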